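Diaryl urea series: chloro in place of trifluoromethyl

The compounds below may be only part of what the source reports. "The series", "measured", "known", "first", "only" and "open" are said of these compounds alone.

Measured so far in a functional assay on 786-0 cells (Homo sapiens) for inhibition, read by sulforhodamine B assay, with a stated time of 48 h, tested at 10 uM; a higher number here means a weaker effect of the compound at the concentration tested, a lower number a stronger effect:
compound 1 `COc1cc2cc(Oc3ccc(NC(=O)Nc4ccccc4)cc3)c(C)nc2cc1OC`: 94.8%
compound 2 `COc1cc2cc(Oc3ccc(NC(=O)Nc4ccc(Cl)c(C(F)(F)F)c4)cc3)c(C)nc2cc1OC`: -21.1%

Compound 2 stands lowest of the two numbers; the nearest is compound 1, separated by the step of a number 115.9 percentage points lower from compound 1 to compound 2 (beyond the scatter), which is beyond the scatter and large. Compound 3 `COc1cc2cc(Oc3ccc(NC(=O)Nc4ccc(Cl)c(Cl)c4)cc3)c(C)nc2cc1OC` is not yet measured. Its change from compound 2 is chloro in place of trifluoromethyl on an aromatic carbon. For the measured compounds named here, the only measured step, from compound 1 to compound 2, concerns a much broader change of the terminal aryl, so it bears on this step only loosely. A small shift, within the scatter, is therefore expected in this assay. Compound 3 is estimated at -12%, range -45% to 30%, meaning an expected step of a number 9.1 percentage points higher from compound 2 to compound 3 (within the scatter).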

Compound 3, a percentage reported as activity, at one concentration (the size of the read-out at that concentration, not a potency): 20.3%
For compound 3 the middle estimate is 32.3 percentage points below the measured one; low and high end bracket the measured number.
By their numbers in this assay, from the lowest: compound 2; then compound 3; then compound 1.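

In this assay, chloro does not serve as an equal replacement for trifluoromethyl at this position on the terminal aryl ring (a number 41.4 percentage points higher from compound 2 to compound 3 (beyond the scatter)). The 3,4-dichlorophenyl group nevertheless retains a large part of the gain over plain phenyl (a number 74.5 percentage points lower from compound 1 to compound 3 (beyond the scatter)). Nothing available explains the difference between the two groups.

Open, as far as these compounds go, is where a methyl or a nitrile at this position would fall relative to compound 2 and compound 3. Also open, from the compounds shown here alone, is how much of the gain over phenyl the 4-chloro group gives on its own.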